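The source may hold more compounds than are shown below. What is called first, only, known or untested is meant among the compounds shown, and "the series" means these compounds.

The series shares one core and varies the arm attached to it. Compound 1 `CCSC(=S)SCC(=O)c1ccc(-c2ccc(CNc3cnc4ccccc4c3)cn2)s1` gives 438 nM in an assay on HEK293 cells for inhibition of protein deacetylase HDAC6 (Homo sapiens); on this read-out higher numbers stand for weaker inhibition and lower numbers for stronger inhibition. Compound 2 `CCSC(=S)SCC(=O)c1cccc(S(=O)(=O)Nc2cccc(C(N)=O)c2)c1` gives 181 nM in this assay. Compound 3 `CCSC(=S)SCC(=O)c1cccc(S(=O)(=O)N(C)c2ccc(OC)cc2)c1` gives 2040 nM in this assay, the highest of the three numbers, beyond the scatter from both compound 1 and compound 2. Compound 4 `CCSC(=S)SCC(=O)c1cccc(S(=O)(=O)Nc2ccc(OC)cc2)c1` has not been measured. It differs from compound 3 in one place: hydrogen in place of methyl on a sulfonamide nitrogen. Within the data shown here, no measured pair in this set differs by that change alone, so the direction must be read from the numbers at hand. Compound 2, which also carries a hydrogen on its sulfonamide nitrogen, gives 181 nM in this assay, although it differs from compound 4 elsewhere as well. The expected step is a 5.1-fold lower number from compound 3 to compound 4 (0.71 log units; beyond the scatter), a move to a lower number beyond the scatter. Compound 4 is estimated at 400 nM in this assay, within a range from 120 nM to 1300 nM.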

Compound 4, half-maximal inhibitory concentration: 519 nM
Beside the measured number, compound 4's estimate is 1.3-fold (0.11 log units) below it; the range from low to high includes it.
By their numbers in this assay, from the lowest: compound 2; then compounds 1 and 4 (each within the scatter of the next); then compound 3.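

In this assay, among these compounds, the change to hydrogen in place of methyl on a sulfonamide nitrogen gives a 3.9-fold lower number from compound 3 to compound 4 (0.59 log units; beyond the scatter) and provides the first direct reading of this position, with the methyl-bearing compound on the higher side. The group on that same nitrogen also shifts the number, as 4-methoxyphenyl in place of 3-carbamoylphenyl gives a 2.9-fold higher number from compound 2 to compound 4 (0.46 log units; beyond the scatter) and so separates two compounds that both carry the hydrogen. Nothing at hand accounts for either step.

As far as these compounds go, it remains open whether an ethyl group on the sulfonamide nitrogen would raise the number as the methyl does, and whether a methyl there would give a step of similar size alongside 3-carbamoylphenyl. A carboxylic acid in place of the carbamoyl group is likewise an open case on that nitrogen's aryl group.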